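Thiophene Swap on a Coumarin-Linked Dienone Series

The source may report more compounds than this note shows. Statements on the series, on what has been measured and on what is new or still open speak of the compounds shown alone.

Measured compounds:
compound 1 `COc1cc(/C=C/C(=O)/C=C/c2cccs2)ccc1OCc1cn(CCOc2cc(=O)oc3ccccc23)nn1`: 12%
compound 2 `COc1cc(/C=C/C(=O)/C=C/c2cc(OC)c(OC)c(OC)c2)ccc1OCc1cn(CCOc2cc(=O)oc3ccccc23)nn1`: 22%
compound 3 `COc1cc(/C=C/C(=O)/C=C/c2cc(OC)c(OC)c(OC)c2)ccc1OCc1cn(CCCCOc2cc(=O)oc3ccccc23)nn1`: 5%

In a functional assay on PC-3 cells (Homo sapiens) for inhibition, read by sulforhodamine B assay, with a stated time of 48 h, tested at 50 uM (on this read-out higher numbers stand for more inhibition of growth at the one concentration tested and lower numbers for less inhibition of growth), compound 2 gives 22% and compound 1 gives 12%. The change between them is thiophen-2-yl in place of 3,4,5-trimethoxyphenyl on a double-bonded chain carbon bound to a double-bonded chain carbon, and it made a step of a number 10 percentage points lower from compound 2 to compound 1 (within the scatter). Compound 3 shares its core with compound 2 only in part; the difference between the two cores is not broken down here. In this assay compound 3 gives 5%, within the scatter of compound 1 and beyond the scatter from compound 2.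

Compound 4 `COc1cc(/C=C/C(=O)/C=C/c2cccs2)ccc1OCc1cn(CCCCOc2cc(=O)oc3ccccc23)nn1` is not yet measured. It differs from compound 3 by thiophen-2-yl in place of 3,4,5-trimethoxyphenyl on a double-bonded chain carbon bound to a double-bonded chain carbon, the same change as from compound 2 to compound 1. Because that step was a number 10 percentage points lower from compound 2 to compound 1 (within the scatter), a similar small step of a number 2 percentage points lower from compound 3 to compound 4 (within the scatter) is expected here, with the low starting value of compound 3 leaving little room downward. For compound 4 the expected value in this assay is 3%, between -6% and 14%.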

Compound 4, percent growth inhibition at one concentration: "not active" (no number reported)
The entry for compound 4 holds no number, so the estimate cannot be set against anything.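

Going by these compounds alone, compound 4 is reported only as "not active", without a number, so no step from compound 3 to compound 4 can be read, and no evidence bears on this result. Still open, as far as these compounds go, is whether thiophen-2-yl in place of 3,4,5-trimethoxyphenyl has the same effect in both compound pairs.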